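A few compounds are considered here, and "the series" means these few. Any claim that something is new, unique, unknown or untested is made for them only; others in the source may bear on it.

- compound 1 `COc1ccc(/C=C/C(=O)/C=C/c2ccc(OCc3cn(CCCOc4cc(=O)oc5ccccc45)nn3)c(OC)c2)cc1`: 53%
- compound 2 `COc1cc(/C=C/C(=O)/C=C/c2cc(OC)c(OC)c(OC)c2)ccc1OCc1cn(CCCOc2cc(=O)oc3ccccc23)nn1`: 74%

Going by the values given here, in a functional assay on COLO 205 cells (Homo sapiens) for inhibition, read by sulforhodamine B assay, with a stated time of 48 h, tested at 50 uM (a higher number here means more inhibition of growth at the concentration tested, a lower number less inhibition of growth), compound 2 gives 74%, the higher of the two numbers measured so far. The next molecule, compound 3 `COc1cc(/C=C/C(=O)/C=C/c2cccs2)ccc1OCc1cn(CCCOc2cc(=O)oc3ccccc23)nn1`, keeps the rest of compound 2 and alters one end of the chain: thiophen-2-yl in place of 3,4,5-trimethoxyphenyl on a double-bonded chain carbon bound to a double-bonded chain carbon. In words, thiophen-2-yl stands in place of 3,4,5-trimethoxyphenyl on a double-bonded chain carbon bound to a double-bonded chain carbon.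

Among the compounds with values here, only one measured step bears on this place. It is a number 21 percentage points higher from compound 1 to compound 2 (beyond the scatter), a modest change that came with 3,4,5-trimethoxyphenyl in place of 4-methoxyphenyl. Compound 3 gives up that same 3,4,5-trimethoxyphenyl group, so a fall of similar size seems the likeliest outcome. Within the data shown here, this is a weak guide, since no compound carrying thiophen-2-yl has been measured and the new ring differs from both earlier ones.

The expected change is a number 18 percentage points lower from compound 2 to compound 3 (beyond the scatter). For compound 3 the estimated value is 56%, with an expected range from 36% to 76%.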

Compound 3, percent growth inhibition at one concentration: 55%
Beside the measured number, compound 3's estimate is 1 percentage points above it; the range from low to high includes it.
By their numbers in this assay, from the lowest: compounds 1 and 3 (each within the scatter of the next); then compound 2.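

In this assay, this place on a double-bonded chain carbon bound to a double-bonded chain carbon now has a second group that falls short of 3,4,5-trimethoxyphenyl: putting thiophen-2-yl there gives a number 19 percentage points lower from compound 2 to compound 3 (beyond the scatter) and shows that the earlier gain does not carry over to this smaller ring. Set against 4-methoxyphenyl, the same thiophen-2-yl gives a number 2 percentage points higher from compound 1 to compound 3 (within the scatter) and so these two different rings cannot be told apart in this test, leaving 3,4,5-trimethoxyphenyl as the only one of the three groups that stands out. Nothing available explains this pattern.

The compounds shown leave open whether the higher number of compound 2 needs all of its methoxy groups, which a dimethoxyphenyl group at this place could test, or whether other rings, such as a pyridine or a furan, could match it. They also leave open how these compounds would compare across a range of concentrations, since each has a reading at only one concentration.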